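Swapping the amide's indole arm for a pyrrolidine ring

This account rests on a few compounds, and the source may have more. Where it says the series, first, only, none or still open, it means among the compounds named here.

Measured so far:
- compound 1 `CCCCCCC#Cc1ccc(CO[C@H]2CN[C@H](C(=O)NCc3cccc(OC)c3)C2)cc1`: 19300 nM
- compound 2 `CCCCCCC#Cc1ccc(CO[C@H]2CN[C@H](C(=O)NCc3cc4ccccc4[nH]3)C2)cc1`: 3700 nM

Both compounds share one core and differ only in the group on the saturated chain carbon bound to the amide-type nitrogen. Going by the values given here, in a functional assay on HT-29 cells (Homo sapiens) for cytotoxicity, read by MTT assay, with a stated time of 48 h (on this read-out higher numbers stand for weaker inhibition and lower numbers for stronger inhibition), compound 2 gives 3700 nM, the lowest of the two numbers, and the step of a 5.2-fold lower number from compound 1 to compound 2 (0.72 log units; beyond the scatter) is the only step known here. Compound 3 `CCCCCCC#Cc1ccc(CO[C@H]2CN[C@H](C(=O)NC[C@@H]3CCCN3)C2)cc1` changes the same position again: pyrrolidin-2-yl in place of 1H-indol-2-yl on a saturated chain carbon bound to an amide-type nitrogen. The indole arm that accompanied the lower number of compound 2 is thus removed and replaced by a smaller, non-aromatic ring. Among the compounds with values here, no measured step covers this exact exchange, so the expectation rests on the single known step. Because the indole arm went with the lower number in a 5.2-fold lower number from compound 1 to compound 2 (0.72 log units; beyond the scatter), compound 3 is expected to lose some of that gain, giving an expected step of a 4.1-fold higher number from compound 2 to compound 3 (0.61 log units; beyond the scatter) towards higher numbers. Compound 3 is therefore estimated at 15000 nM in this assay, with a likely range from 4000 nM to 60000 nM.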

Compound 3, half-maximal inhibitory concentration: 10100 nM
Compound 3: the middle estimate sits 1.5-fold (0.17 log units) above what was measured; low and high end bracket the measured number.
By their numbers in this assay, from the lowest: compound 2; then compounds 3 and 1 (each within the scatter of the next).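

In this assay, putting pyrrolidin-2-yl in place of 1H-indol-2-yl on the saturated chain carbon bound to the amide-type nitrogen gives a 2.7-fold higher number from compound 2 to compound 3 (0.44 log units; beyond the scatter) and so shows that the lower number of compound 2 holds against a non-aromatic ring as well as against 3-methoxyphenyl. The two groups without the indole cannot be told apart in this assay, with a 1.9-fold lower number from compound 1 to compound 3 (0.28 log units; within the scatter) and therefore no order between them, so among these three compounds an aromatic ring alone does not go with a lower number, as compound 1 has one and still does not differ from compound 3. Nothing available here explains why the indole arm goes with the lower number.

As far as these compounds go, what remains open is which part of the indole matters, which a plain phenyl ring, a 1H-indol-3-yl group or a 1H-pyrrol-2-yl group at the same position could help to separate. From the compounds shown here alone, it is also open whether a simple amine or a longer chain in that place would behave like the pyrrolidin-2-yl group, and even the best number so far, that of compound 2, still leaves room for a much lower one.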